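The compounds below may be only part of what the source reports. "The series", "measured", "known", "first", "only" and "open" are said of these compounds alone.

Measured in a functional assay on HeLa cells (Homo sapiens) for cytotoxicity, read by sulforhodamine B assay, with a stated time of 48 h; a lower number here means a stronger inhibitor, a higher number a weaker inhibitor:
- compound 1 `C=CCOc1ccc(F)cc1C(=O)c1cccnc1`: 93000 nM
- compound 2 `C=CCOc1cc(Br)ccc1C(=O)c1cccnc1`: > 100000 nM

The entry for compound 2 is a limit, > 100000 nM, and not a number. Among the compounds with values here, compound 1 therefore holds the only numeric value in the set, 93000 nM, so its standing cannot be ranked against a second number.

Compound 3 `O=C(c1cccnc1)c1cc(F)ccc1O` is the next to be read. It carries hydrogen in place of allyl on an oxygen on an aromatic ring, allyloxy to hydroxy: hydrogen in place of allyl on an oxygen on an aromatic ring. Within the data shown here, no measured pair shows this change, so the only anchor is compound 1 at 93000 nM. In this assay no step beyond the scatter is expected, and a reading reported only as a limit remains possible.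

The expected 1.2-fold lower number from compound 1 to compound 3 (0.07 log units; within the scatter) is small. The estimate for compound 3 is 80000 nM, with an expected range of 30000 nM to 150000 nM.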

Compound 3, half-maximal inhibitory concentration: 27000 nM
Beside the measured number, compound 3's estimate is 3.0-fold (0.47 log units) above it; the whole stated range lies above it.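

In this assay, the allyl on the oxygen on an aromatic ring is not required for the cytotoxic read-out: hydrogen in its place gives a 3.4-fold lower number from compound 1 to compound 3 (0.54 log units; beyond the scatter). Within the data shown here, this is the first step that can be read, and it shows that this position responds to change, with the hydroxy compound the stronger of the pair. The step is modest and rests on a single pair, so it marks a direction at this oxygen and not a trend.

As far as these compounds go, whether a methyl group, a longer chain or a chain ending in an amine on this oxygen would read closer to hydroxy or to allyl stays open. Compound 2 is a limit and not a number, and whether the same change would move it also stays open: the limit of > 100000 nM in this assay, at which 1 of the 3 values shown sits.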